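The source may report more compounds than this note shows. Statements on the series, on what has been measured and on what is new or still open speak of the compounds shown alone.

Of the compounds shown here, three have been measured so far in a functional assay on MCF7 cells (Homo sapiens) for antiproliferative activity, read by sulforhodamine B assay, with a stated time of 72 h (a higher number here means a weaker inhibitor, a lower number a stronger inhibitor), on this series. Compound 1 (`O=C(Cn1nc(-c2ccccc2)c2ccccc2c1=O)Nc1ccccc1Cl`) gives 30000 nM there, compound 2 (`O=C(Cn1nc(Cc2ccccc2)c2ccccc2c1=O)Nc1ccccc1`) gives 36000 nM there, and compound 3 (`COc1ccc(NC(=O)Cn2nc(Cc3ccccc3)c3ccccc3c2=O)cc1`) gives 62000 nM there. Compound 3 thus lies within the scatter of compound 2, and just beyond the scatter on the higher side of compound 1. Compound 4 (`O=C(Cn1nc(Cc2ccccc2)c2ccccc2c1=O)Nc1ccccc1Cl`) has 2-chlorophenyl in place of 4-methoxyphenyl on an amide-type nitrogen. For the measured compounds named here, the one measured step at this group (a 1.7-fold higher number from compound 2 to compound 3 (0.24 log units; within the scatter)) stayed within the scatter, with methoxy in place of hydrogen on an aromatic carbon. That single small step gives no reason to expect a larger one here, so the estimate is a change within the scatter in this assay (a 1.6-fold lower number from compound 3 to compound 4 (0.21 log units; within the scatter)). For compound 4 the estimated value is 38000 nM, with 18000 nM to 75000 nM as the expected range.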

Compound 4, half-maximal inhibitory concentration: 89000 nM
The estimate for compound 4 lay 2.3-fold (0.37 log units) below the measured number, outside the stated range (above it).
By their numbers in this assay, from the lowest: compounds 1, 2, 3 and 4 (each within the scatter of the next, the first and the last beyond it).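

In this assay, for the compounds shown here, 2-chlorophenyl in place of 4-methoxyphenyl on the amide-type nitrogen stays within the scatter (a 1.4-fold higher number from compound 3 to compound 4 (0.16 log units; within the scatter)), whereas chloro in place of hydrogen on an aromatic carbon gives the first step at this group beyond the scatter, a modest rise towards weaker inhibition (a 2.5-fold higher number from compound 2 to compound 4 (0.39 log units; beyond the scatter)). Benzyl in place of phenyl on an aromatic carbon also gives a modest rise beyond the scatter (a 3.0-fold higher number from compound 1 to compound 4 (0.47 log units; beyond the scatter)), so a change elsewhere on the molecule moves the number too. No evidence here accounts for these steps. Going by these compounds, whether an amine or a carboxylic acid in place of the chloro, or a longer chain in place of benzyl, would give a lower number remains open.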